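A chain swap from compound 3 to compound 4

The compounds below may be only part of what the source reports. "The series", "measured", "known", "first", "only" and "open" are said of these compounds alone.

In a functional assay on MCF7 cells (Homo sapiens) for cytotoxicity, read by colorimetric assay and MTT assay (on this read-out lower numbers stand for stronger inhibition and higher numbers for weaker inhibition), compound 1 `COc1cc(OC)c2cc(-c3ccccc3)c(O)nc2c1` gives 10000 nM, compound 2 `COc1cc(OC)c2cc(-c3ccc(OCc4ccccc4)cc3)c(O)nc2c1` gives 10000 nM and compound 3 `CCOC(=O)Cn1c(=O)c(-c2ccc(OC)cc2)cc2c(OC)cc(OC)cc21` gives 10000 nM, so compound 3 stands level with the other two. Compound 4 `COc1ccc(-c2cc3c(OC)cc(OC)cc3n(CCCC#N)c2=O)cc1` differs from compound 3 by one change: 2-cyanoethyl in place of ethoxycarbonyl on a saturated chain carbon bound to an aromatic nitrogen. In plain terms, 2-cyanoethyl replaces ethoxycarbonyl on a saturated chain carbon bound to an aromatic nitrogen. For the measured compounds named here, only one measured step offers any guide, and it shows no change at the digits printed from compound 1 to compound 2 (within the scatter). Going by the values given here, that step adds benzyloxy on an aromatic carbon, so it does not touch this chain, and no measured step does. The expected result, with no direction favoured, is no change at the digits printed from compound 3 to compound 4 (within the scatter). For compound 4 the estimated value is 10000 nM, with an expected range from 3000 nM to 20000 nM.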

Compound 4, half-maximal inhibitory concentration: 10000 nM
Estimate against measurement, compound 4: no gap at the digits printed; low and high end bracket the measured number.
By their numbers in this assay, from the lowest: compounds 1, 2, 3 and 4 (each within the scatter of the next).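

In this assay, for the compounds shown here, putting 2-cyanoethyl in place of ethoxycarbonyl on a saturated chain carbon bound to an aromatic nitrogen gives no change at the digits printed from compound 3 to compound 4 (within the scatter) and is the first measured step at this place. The chain can therefore end in ethoxycarbonyl or in a nitrile with the same printed reading. No available evidence offers an explanation for this result.

As far as these compounds go, whether an amine or a carboxylic acid on this chain, or a longer chain, would lower the number stays open. All four compounds read alike, so nothing shown yet identifies a change at this place that moves the read-out.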